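Replacing the side group on the carbonyl of compound 3

A few compounds are considered here, and "the series" means these few. Any claim that something is new, unique, unknown or untested is made for them only; others in the source may bear on it.

- compound 1 `Cc1c(C(=O)OCCCN(C)C)oc2ccc(N(Cc3ccc(Br)cc3)S(=O)(=O)c3ccc(Br)cc3)cc12` gives 39700 nM
- compound 2 `Cc1c(C(=O)NCCS(C)(=O)=O)oc2ccc(N(Cc3ccc(Br)cc3)S(=O)(=O)c3ccc(Br)cc3)cc12` gives > 40000 nM (a limit, not a number)
- compound 3 `Cc1c(C(=O)NCC(O)CO)oc2ccc(N(Cc3ccc(Br)cc3)S(=O)(=O)c3ccc(Br)cc3)cc12` gives 36500 nM

All three were tested in a functional assay on MCF7 cells (Homo sapiens) for antiproliferative activity, read by MTT assay, with a stated time of 48 h (a higher number here means a weaker inhibitor, a lower number a stronger inhibitor), and share one core. Compound 3 at 36500 nM and compound 1 at 39700 nM sit within the scatter of each other. Compound 2 reaches only the limit > 40000 nM of this test, so it has no exact number.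

Compound 4 `Cc1c(C(=O)N2CCCC(C)C2)oc2ccc(N(Cc3ccc(Br)cc3)S(=O)(=O)c3ccc(Br)cc3)cc12` has 3-methylpiperidin-1-yl in place of the (2,3-dihydroxypropyl)amino of compound 3, on a carbonyl carbon 3-methylpiperidin-1-yl in place of (2,3-dihydroxypropyl)amino on a carbonyl carbon and nothing else differs.

The three measured steps all change the group at this same carbonyl carbon. The step of a 1.1-fold lower number from compound 1 to compound 3 (0.04 log units; within the scatter) is the only one with a readable size, and it stays within the scatter. The step of an at least 1.0-fold lower number from compound 2 to compound 3 (0.03 log units; that floor lies within the scatter) has a floor within the scatter, and the step of a number no lower from compound 1 to compound 2 (the limit leaves the size open) has a size that the limit leaves open. None of compounds 1 to 3 carries a ring in this group, so these steps are only a loose guide.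

The expected step of a 1.2-fold lower number from compound 3 to compound 4 (0.09 log units; within the scatter) is no shift beyond the scatter in this assay and the result could also be only a limit. The estimate for compound 4 is 30000 nM with an expected range from 12000 nM to 45000 nM in this test.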

Compound 4, half-maximal inhibitory concentration: 32800 nM
Beside the measured number, compound 4's estimate is 1.1-fold (0.04 log units) below it, and the stated range covers the measured number.
By their numbers in this assay, from the lowest: compounds 4, 3 and 1 (each within the scatter of the next). At a limit, above all of these: compound 2.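

In this assay, 3-methylpiperidin-1-yl brings the first ring to this carbonyl carbon, and it has 0 hydrogen-bond donors and 0 hydrogen-bond acceptors where (2,3-dihydroxypropyl)amino has 3 and 2. Even so, the result is a 1.1-fold lower number from compound 3 to compound 4 (0.05 log units; within the scatter), and the comparison with the ester gives a 1.2-fold lower number from compound 1 to compound 4 (0.08 log units; within the scatter), so compounds 1, 3 and 4 cannot be told apart in this test, whether or not this position carries a ring or any hydrogen-bond donors. Compound 2 holds a limit and not a number, so its step reads only as an at least 1.2-fold lower number from compound 2 to compound 4 (0.08 log units; that floor lies within the scatter), and it rests on a single value of this kind: the limit of > 40000 nM in this assay, at which 1 of the 4 values shown sits.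

From the compounds shown here alone, every step with a readable size stays within the scatter, so it remains open whether any group on this carbonyl carbon can move the number beyond it, for instance a carboxylic acid on a longer chain or a piperazine ring with its second amine nitrogen. Going by these compounds, the part played by the methyl of 3-methylpiperidin-1-yl is also open, and plain piperidin-1-yl would be the direct comparison for it.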